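The compounds below may be only part of what the source reports. "The series", "measured", "known", "first", "only" and "open" are said of these compounds alone.

Measured so far:
- compound 1, `Cc1noc(C)c1-c1ccc2c(c1)C(c1ccccc1)NC(=O)N2C`: 33.5%
- compound 2, `Cc1noc(C)c1-c1ccc2c(c1)C(c1ccccc1)N(Cc1ncc(-c3ccccc3)o1)C(=O)N2C`: 34%
- compound 3, `Cc1nc(-c2ccccc2)sc1CN1C(=O)N(C)c2ccc(-c3c(C)noc3C)cc2C1c1ccccc1`: 35.1%

All three values come from a functional assay on MCF7 cells (Homo sapiens) for inhibition, read by MTT assay, with a stated time of 48 h, tested at 2 uM; a lower number here means less inhibition, a higher number more inhibition at the concentration tested (going by the name of the read-out). Compound 3 gives the highest of the three numbers, but both of its neighbours lie within the scatter of it: compound 2 is nearest, and compound 1 furthest, each by a gap that repeated measurement could erase. Among the measured compounds shown here, no compound here can be said to give a higher number than the others.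

Compound 4 is `Cc1noc(C)c1-c1ccc2c(c1)C(c1ccccc1)N(Cc1nnc(-c3ccccc3)s1)C(=O)N2C`, not yet measured. It differs from compound 3 in one place: 5-phenyl-1,3,4-thiadiazol-2-yl in place of 4-methyl-2-phenyl-1,3-thiazol-5-yl on a saturated chain carbon bound to an amide-type nitrogen in a ring

For the measured compounds named here, two measured steps bear on this. Adding the whole chain to the ring nitrogen gave a number 0.5 percentage points higher from compound 1 to compound 2 (within the scatter), and swapping one aromatic group for another on that same chain carbon gave a number 1.1 percentage points higher from compound 2 to compound 3 (within the scatter). Both were within the scatter, so another swap of the aromatic group at that position is expected to give no step beyond the scatter in this assay, in either direction; this expectation means a number 1.1 percentage points lower from compound 3 to compound 4 (within the scatter).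

Compound 4 is therefore estimated at 34%, with a range from 24% to 44%.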

Compound 4, a percentage reported as inhibition, at one concentration (the size of the read-out at that concentration, not a potency): 35.7%
Beside the measured number, compound 4's estimate is 1.7 percentage points below it; the measured number falls inside the stated range.
By their numbers in this assay, from the lowest: compounds 1, 2, 3 and 4 (each within the scatter of the next).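

In this assay, a third aromatic group on the saturated chain carbon, 5-phenyl-1,3,4-thiadiazol-2-yl, changes little, with a number 0.6 percentage points higher from compound 3 to compound 4 (within the scatter) against 4-methyl-2-phenyl-1,3-thiazol-5-yl and with a number 1.7 percentage points higher from compound 2 to compound 4 (within the scatter) against 5-phenyl-1,3-oxazol-2-yl. Three different five-membered aromatic rings, each carrying a phenyl, can therefore not be told apart at this position in this read-out. The comparison with hydrogen on the ring nitrogen, with a number 2.2 percentage points higher from compound 1 to compound 4 (within the scatter) for the (5-phenyl-1,3,4-thiadiazol-2-yl)methyl group, shows that this third group also cannot be told apart from having no chain at all.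

Still open, going by these compounds, is whether a group of another kind on this nitrogen, such as an amine or a carboxylic acid at the end of a longer chain, would move the number beyond the scatter. The data offer no measurement that could explain why these changes leave the number so flat.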